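Amine substituent exchange on the shared core: compound 4

The compounds below may be only part of what the source reports. "The series", "measured", "known", "first", "only" and "open" are said of these compounds alone.

compound 1 `CCCCNc1nc(C(F)(F)F)ccc1CNC(=O)C(C)c1ccc(NS(C)(=O)=O)c(F)c1`: a functional assay on CHO-K1 cells for antagonist activity at transient receptor potential cation channel subfamily V member 1 (Homo sapiens), read by FLIPR (a lower number here means a stronger inhibitor, a higher number a weaker inhibitor), 293 nM
compound 2 `CC(C(=O)NCc1ccc(C(F)(F)F)nc1NC1CCCCC1)c1ccc(NS(C)(=O)=O)c(F)c1`: 260 nM
compound 3 `CC(C(=O)NCc1ccc(C(F)(F)F)nc1NCC1CCN(C(=O)OC(C)(C)C)CC1)c1ccc(NS(C)(=O)=O)c(F)c1`: 1140 nM

Compound 2 and compound 1 lie within the scatter of each other; compound 3 stands clearly higher than compound 2. Compound 4 `CC(C(=O)NCc1ccc(C(F)(F)F)nc1Nc1ccccc1)c1ccc(NS(C)(=O)=O)c(F)c1` differs from compound 2 by phenyl in place of cyclohexyl on a nitrogen on an aromatic ring. For the measured compounds named here, the one single-site step measured at this nitrogen is a 1.1-fold lower number from compound 1 to compound 2 (0.05 log units; within the scatter), so a butyl to cyclohexyl exchange there changed little; the values of compound 2 and compound 3 show that a different substituent on that nitrogen can give a clearly higher number. Nothing measured bears on an aromatic ring in this place. A step in this assay of modest size at most is expected, direction uncertain: a 1.3-fold higher number from compound 2 to compound 4 (0.13 log units; within the scatter). Compound 4 is estimated at 350 nM, range 120 nM to 1000 nM.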

Compound 4, half-maximal inhibitory concentration: 1400 nM
For compound 4 the middle estimate is 4.0-fold (0.60 log units) below the measured one; the measured number lies above the stated range.
By their numbers in this assay, from the lowest: compounds 2 and 1 (each within the scatter of the next); then compounds 3 and 4 (each within the scatter of the next).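

In this assay the nitrogen on the aromatic ring proves sensitive to the phenyl exchange: phenyl in place of cyclohexyl (a 5.4-fold higher number from compound 2 to compound 4 (0.73 log units; beyond the scatter)) and phenyl in place of butyl (a 4.8-fold higher number from compound 1 to compound 4 (0.68 log units; beyond the scatter)) both lie beyond the scatter, while butyl to cyclohexyl (a 1.1-fold lower number from compound 1 to compound 2 (0.05 log units; within the scatter)) stays within it. Cyclohexyl and phenyl carry the same count of heavy atoms, so within this pair an aromatic ring in place of a non-aromatic one suffices for the step. No measurement at hand accounts for this shift.

Open, as far as these compounds go, is whether a benzyl group or a pyridyl ring on this nitrogen would track with compound 4 or with compound 2. Also open, from the compounds shown here alone, is how a fluorine or methoxy group on the phenyl ring would move the number.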